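Chloro removal on a triazolethione series: expected effect

A few compounds are considered here, and "the series" means these few. Any claim that something is new, unique, unknown or untested is made for them only; others in the source may bear on it.

Compound 1 `COc1ccc(-n2c(Nc3nc(-c4ccccc4)cs3)n[nH]c2=S)cc1`: 100 mg/kg
Compound 2 `COc1ccc(-n2c(Nc3nc(-c4ccc(Cl)cc4)cs3)n[nH]c2=S)cc1`: 100 mg/kg
Compound 3 `Cc1ccc(-n2c(Nc3nc(-c4ccc(Cl)cc4)cs3)n[nH]c2=S)cc1`: 300 mg/kg

In a functional assay on the whole organism (strain Swiss albino) for inhibition, with Mus musculus as the target, with a stated time of 4 h (on this read-out lower numbers stand for an effect already at smaller amounts and higher numbers for an effect only at larger amounts of compound), compound 1 gives 100 mg/kg, compound 2 gives 100 mg/kg and compound 3 gives 300 mg/kg. Compound 2 and compound 3 differ in the core, where the change methyl in place of methoxy on an aromatic carbon produced the step of a 3.0-fold higher number from compound 2 to compound 3 (0.48 log units; beyond the scatter). The change hydrogen in place of chloro on an aromatic carbon produced no change at the digits printed from compound 2 to compound 1 (within the scatter). Compound 4 `Cc1ccc(-n2c(Nc3nc(-c4ccccc4)cs3)n[nH]c2=S)cc1` is not yet measured; it arises from compound 3 by hydrogen in place of chloro on an aromatic carbon, the same change in the same place, seen in two pairs among these compounds. The step from compound 3 to compound 4 is expected to be about no change at the digits printed from compound 3 to compound 4 (within the scatter), because the earlier step of no change at the digits printed from compound 2 to compound 1 (within the scatter) stayed within the scatter. Compound 4 is therefore estimated at 300 mg/kg, between 150 mg/kg and 600 mg/kg.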

Compound 4, minimum effective dose: 300 mg/kg
For compound 4 middle estimate and measured number coincide at the digits printed; the measured number falls inside the stated range.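

Taking the chloro off in this assay gives no change at the digits printed from compound 3 to compound 4 (within the scatter), which matches the same change on the compounds carrying methoxy: the same change on two cores in this assay, no change at the digits printed (within the scatter) from compound 2 to compound 1 and no change at the digits printed (within the scatter) from compound 3 to compound 4, 1.0-fold (0.00 log units) apart, within the scatter of two such steps

Putting methyl in place of methoxy gives a 3.0-fold higher number from compound 1 to compound 4 (0.48 log units; beyond the scatter), which matches the same change on the compounds carrying chloro: the same change on two cores in this assay, a 3.0-fold higher number (0.48 log units; beyond the scatter) from compound 2 to compound 3 and a 3.0-fold higher number (0.48 log units; beyond the scatter) from compound 1 to compound 4, 1.0-fold (0.00 log units) apart, within the scatter of two such steps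

So each change carried over between these two related cores, but two pairs cannot show that it would carry over to other cores, and they do not explain why either change behaves as it does.

The compounds shown leave open what an amine or a carboxylic acid would do in the place of the chloro. They also leave open what a longer chain would do in the place of the methoxy.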